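This account rests on a few compounds, and the source may have more. Where it says the series, first, only, none or still open, it means among the compounds named here.

Three members of the series carry numbers in a functional assay on HCT-116 cells (Homo sapiens) for inhibition, read by sulforhodamine B assay, with a stated time of 48 h; a lower number here means a stronger inhibitor of growth, a higher number a weaker inhibitor of growth. Compound 1 `O=C(Nc1cccc(-n2cc(-c3ccncc3)c(-c3ccc(Cl)c(O)c3)n2)c1)Nc1cccc(C(F)(F)F)c1` gives 1390 nM, compound 2 `O=C(Nc1cccc(-n2cc(-c3ccncc3)c(-c3ccc(Cl)c(O)c3)n2)c1)Nc1ccc(Cl)c(Cl)c1` gives 1190 nM, and compound 3 `COc1cc(-c2nn(-c3cccc(NC(=O)Nc4ccc(Cl)c(C(F)(F)F)c4)c3)cc2-c2ccncc2)ccc1Cl` gives 1170 nM. For the measured compounds named here, the single measured step with one change, a 1.2-fold lower number from compound 1 to compound 2 (0.07 log units; within the scatter), concerns the aryl on the amide-type nitrogen and stays within the scatter. Compound 3 has the lowest of the three numbers, yet its gap to compound 2 and to compound 1 is within the scatter, so the three stand together.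

Compound 4 `O=C(Nc1cccc(-n2cc(-c3ccncc3)c(-c3ccc(Cl)c(O)c3)n2)c1)Nc1ccc(Cl)c(C(F)(F)F)c1` differs from compound 3 in one place: hydrogen in place of methyl on an oxygen on an aromatic ring. Going by the values given here, no measured step isolates this change. Compounds 1 and 2 carry the hydroxy while compound 3 carries the methoxy, and their numbers sit within the scatter of one another, although the aryl on the amide-type nitrogen differs as well. The expected step, a 1.0-fold higher number from compound 3 to compound 4 (0.01 log units; within the scatter), is therefore nothing beyond the scatter in this assay. Compound 4 is estimated at 1200 nM, within 600 nM to 2400 nM in this assay.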

Compound 4, concentration for 50% growth inhibition: 998 nM
Estimate against measurement, compound 4: 1.2-fold (0.08 log units) above; low and high end bracket the measured number.
By their numbers in this assay, from the lowest: compounds 4, 3, 2 and 1 (each within the scatter of the next).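

Working from this assay, the step of a 1.2-fold lower number from compound 3 to compound 4 (0.07 log units; within the scatter) isolates methoxy to hydroxy for the first time and stays within the scatter, so hydrogen in place of methyl on this oxygen leaves the number unresolved from that of the methoxy compound. With the hydroxy held constant, the step of a 1.2-fold lower number from compound 2 to compound 4 (0.08 log units; within the scatter) for trifluoromethyl in place of chloro and the step of a 1.4-fold lower number from compound 1 to compound 4 (0.14 log units; within the scatter) for chloro in place of hydrogen also stay within the scatter, so neither change on an aromatic carbon separates these compounds. No available evidence bears on why these changes leave the number unresolved.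

Going by these compounds, whether a longer chain on this oxygen, or an amine or carboxylic acid in place of the hydroxy, would give a step beyond the scatter stays open. On these data alone, compounds 1 to 4 also share the core, so the dependence of the number on that core remains untested here.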